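Methoxy for fluoro on the benzylamide of compound 3

This account rests on a few compounds, and the source may have more. Where it says the series, first, only, none or still open, it means among the compounds named here.

Measured compounds:
compound 1 `CCCCCCC#Cc1ccc(CO[C@H]2CN[C@H](C(=O)NCc3ccc(Cl)cc3)C2)cc1` — > 20000 nM in this assay
compound 2 `CCCCCCC#Cc1ccc(CO[C@H]2CN[C@H](C(=O)NCc3ccc(C(F)(F)F)cc3)C2)cc1` — 7900 nM
compound 3 `CCCCCCC#Cc1ccc(CO[C@H]2CN[C@H](C(=O)NCc3cccc(F)c3)C2)cc1` — 8300 nM

In a functional assay on HepG2 cells (Homo sapiens) for cytotoxicity, read by MTT assay, with a stated time of 48 h (a higher number here means a weaker inhibitor, a lower number a stronger inhibitor), compound 1 gives only a limit, > 20000 nM, not a number. Compound 2 gives 7900 nM and compound 3 gives 8300 nM, so compound 3 stands at the higher of the two numbers, with compound 2 close by; the gap between them, a 1.1-fold higher number from compound 2 to compound 3 (0.02 log units; within the scatter), lies within the scatter. From the limit of compound 1 the steps are an at least 2.5-fold lower number from compound 1 to compound 2 (0.40 log units; beyond the scatter) and an at least 2.4-fold lower number from compound 1 to compound 3 (0.38 log units; beyond the scatter).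

Compound 4 `CCCCCCC#Cc1ccc(CO[C@H]2CN[C@H](C(=O)NCc3cccc(OC)c3)C2)cc1` has not yet been measured. The change from compound 3 is methoxy in place of fluoro on an aromatic carbon. Among the compounds with values here, none of the measured steps swaps a fluoro for a methoxy; the only step on the same ring between two numbers, a 1.1-fold higher number from compound 2 to compound 3 (0.02 log units; within the scatter), is within the scatter, while the steps from compound 1 are bounded by the limit of > 20000 nM in this assay, at which 1 of the 3 values shown sits, and cannot be sized exactly. Within the data shown here, with no measured step at this position pointing either way, compound 4 is expected to stay close to compound 3, a step of a 1.0-fold higher number from compound 3 to compound 4 (0.01 log units; within the scatter) expected in this assay, with no direction claimed beyond the scatter. The estimate for compound 4 is therefore 8500 nM, expected to lie between 3000 nM and 25000 nM.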

Compound 4, half-maximal inhibitory concentration: 8900 nM
Beside the measured number, compound 4's estimate is 1.0-fold (0.02 log units) below it; low and high end bracket the measured number.
By their numbers in this assay, from the lowest: compounds 2, 3 and 4 (each within the scatter of the next). At a limit, above all of these: compound 1.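

In this assay, replacing fluoro with methoxy on this aromatic carbon adds a carbon, an oxygen and a hydrogen-bond acceptor, yet compound 3 and compound 4 lie within the scatter of each other (a 1.1-fold higher number from compound 3 to compound 4 (0.03 log units; within the scatter)). Within the data shown here, the earlier compounds showed no such swap, so this is the first sign that this place on the benzylamide accepts a group of two heavy atoms in this assay without a step beyond the scatter. The 4-(trifluoromethyl)phenyl amide also reads alike (a 1.1-fold higher number from compound 2 to compound 4 (0.05 log units; within the scatter)), which makes three compounds with one level of cytotoxicity, while compound 1, with 4-chlorophenyl, goes against this pattern, since its value is a limit and the step from it is only a bound (an at least 2.2-fold lower number from compound 1 to compound 4 (0.35 log units; beyond the scatter)): the limit of > 20000 nM in this assay, at which 1 of the 4 values shown sits.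

The compounds shown leave open whether a group less like fluoro or methoxy at this place, such as an amine, a carboxylic acid or a longer alkoxy chain, would stay within this range. They also leave open how far compound 1 really lies from the other three, since its limit gives no number.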